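Thiophen-2-yl in place of phenyl: a step within the scatter?

A few compounds are considered here, and "the series" means these few. Any claim that something is new, unique, unknown or untested is made for them only; others in the source may bear on it.

In a functional assay on HCT-116 cells (Homo sapiens) for inhibition, read by sulforhodamine B assay, with a stated time of 48 h, tested at 50 uM (on this read-out lower numbers stand for less inhibition of growth and higher numbers for more inhibition of growth at the one concentration tested), compound 3 `COc1cc(/C=C/C(=O)/C=C/c2ccccc2)ccc1OCc1cn(CCCOc2cc(=O)oc3ccccc23)nn1` gives 45%. Two compounds that share its core have also been measured: compound 1 `COc1cc(/C=C/C(=O)/C=C/c2ccco2)ccc1OCc1cn(CCCOc2cc(=O)oc3ccccc23)nn1` gives 51%, and compound 2 `COc1ccc(/C=C/C(=O)/C=C/c2ccc(OCc3cn(CCCOc4cc(=O)oc5ccccc45)nn3)c(OC)c2)cc1` gives 54%. All three values lie within the scatter of one another, so compound 3 cannot be set apart from either.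

Compound 4 `COc1cc(/C=C/C(=O)/C=C/c2cccs2)ccc1OCc1cn(CCCOc2cc(=O)oc3ccccc23)nn1` has not yet been measured. It differs from compound 3 on a double-bonded chain carbon bound to a double-bonded chain carbon: thiophen-2-yl in place of phenyl on a double-bonded chain carbon bound to a double-bonded chain carbon.

The nearest evidence comes from exchanges at that same place. With phenyl in place of furan-2-yl, the data show a number 6 percentage points lower from compound 1 to compound 3 (within the scatter). With 4-methoxyphenyl in place of furan-2-yl, they show a number 3 percentage points higher from compound 1 to compound 2 (within the scatter). The remaining comparison, hydrogen in place of methoxy on an aromatic carbon, gives a number 9 percentage points lower from compound 2 to compound 3 (within the scatter). Among the compounds with values here, none of these three steps leaves the scatter, although no compound carrying thiophen-2-yl has yet been tested. The expected result is therefore no real shift, and the estimated step is a number 3 percentage points higher from compound 3 to compound 4 (within the scatter), which stays within the scatter. For compound 4 the estimated value is 48%, with an expected range of 37% to 60%.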

Compound 4, percent growth inhibition at one concentration: 58%
Compound 4: the middle estimate sits 10 percentage points below what was measured; measured number inside the range.
By their numbers in this assay, from the lowest: compounds 3, 1, 2 and 4 (each within the scatter of the next, the first and the last beyond it).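

In this assay, thiophen-2-yl in place of phenyl on a double-bonded chain carbon bound to a double-bonded chain carbon gives a number 13 percentage points higher from compound 3 to compound 4 (beyond the scatter), the only step among these compounds that leaves the scatter, which shows that a change at this position can move the read-out, if modestly. The step does not set thiophen-2-yl apart from the other groups at this place: the data show a number 4 percentage points higher from compound 2 to compound 4 (within the scatter) with thiophen-2-yl in place of 4-methoxyphenyl and a number 7 percentage points higher from compound 1 to compound 4 (within the scatter) with thiophen-2-yl in place of furan-2-yl, so the separation holds for the pair with phenyl alone. No evidence is available that bears on the reason for this step.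

The compounds shown leave open how a pyridin-2-yl group, an aminophenyl group or a carboxylic acid at the same place would read out. They also leave open whether the step seen here would persist at other concentrations, since every value comes from a single tested concentration.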